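Replacing 2-hydroxyethyl with 4-hydroxycyclohexyl on the shared core

This account rests on a few compounds, and the source may have more. Where it says the series, first, only, none or still open, it means among the compounds named here.

Measured so far in a functional assay on LNCaP cells (Homo sapiens) for cytotoxicity; on this read-out higher numbers stand for weaker inhibition and lower numbers for stronger inhibition:
compound 1 `CNC(=O)Nc1ccc(-c2nc(N3CC4CCC(C3)O4)c3cnn(CCO)c3n2)cc1`: 650 nM
compound 2 `O=C(Nc1ccncc1)Nc1ccc(-c2nc(N3CC4CCC(C3)O4)c3cnn(C4CCC5(CC4)OCCO5)c3n2)cc1`: 1 nM
compound 3 `O=C(Nc1ccc(-c2nc(N3CC4CCC(C3)O4)c3cnn(C4CCC5(CC4)OCCO5)c3n2)cc1)NC1CC1`: 2 nM

Of these three, compound 1 stands highest, at 650 nM. Compound 4 `CNC(=O)Nc1ccc(-c2nc(N3CC4CCC(C3)O4)c3cnn([C@H]4CC[C@H](O)CC4)c3n2)cc1` keeps the core of compound 1 and changes one group: 4-hydroxycyclohexyl in place of 2-hydroxyethyl on an aromatic nitrogen. In short, 4-hydroxycyclohexyl replaces 2-hydroxyethyl on an aromatic nitrogen. Within the data shown here, no measured step covers that place. Among the measured compounds shown here, the only step available, a 2.0-fold higher number from compound 2 to compound 3 (0.30 log units; within the scatter), lies elsewhere in the structure. Compound 2 and compound 3 carry a different ring-bearing group on that nitrogen but also differ from compound 1 at the other end, so they point only loosely towards a lower number in this assay. A sizeable drop is therefore expected, the estimated step being a 9.3-fold lower number from compound 1 to compound 4 (0.97 log units; beyond the scatter). Compound 4 is estimated at 70 nM, with an expected range of 12 nM to 400 nM.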

Compound 4, half-maximal inhibitory concentration: 20 nM
Compound 4: the middle estimate sits 3.5-fold (0.54 log units) above what was measured; the measured number falls inside the stated range.
By their numbers in this assay, from the lowest: compounds 2 and 3 (each within the scatter of the next); then compound 4; then compound 1.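

In this assay, among these compounds, this is the first measured change on the aromatic nitrogen with the rest of the structure held the same: 4-hydroxycyclohexyl in place of 2-hydroxyethyl gives a 33-fold lower number from compound 1 to compound 4 (1.51 log units; beyond the scatter). The position therefore bears strongly on this read-out, and the step comes with a six-membered carbon ring entering while the hydrogen-bond donor and acceptor counts stay unchanged. Nothing at hand explains the step.

As far as these compounds go, it remains open whether the carbon ring alone carries this step or the hydroxyl also matters; plain cyclohexyl or 4-aminocyclohexyl on that nitrogen would separate the two.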